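The source may report more compounds than this note shows. Statements on the series, on what has been measured and on what is new or still open speak of the compounds shown alone.

Compound 1 `CC1(C)C(=O)NC(c2ccc(N)cc2)c2ccccc21` gives 20 mg/kg in a functional assay on the whole organism with Mus musculus as the target, in the maximal electroshock model, with a stated time of 3 h (on this read-out lower numbers stand for an effect already at smaller amounts and higher numbers for an effect only at larger amounts of compound), the second highest of the three numbers measured; compound 2 `CCCNCC(=O)Nc1ccc(C2NC(=O)C(C(C)C)c3ccccc32)cc1` gives 19.6 mg/kg, within the scatter of compound 1, while compound 3 `CCN(CC)CC(=O)Nc1ccc(C2NC(=O)C(C)(C)c3ccccc32)cc1` gives 90 mg/kg. Compound 4 `CC1(C)C(=O)NC(c2ccc(NC(=O)CN3CCCCC3)cc2)c2ccccc21` differs from compound 1 by ((piperidin-1-yl)methyl)carbonyl in place of hydrogen on a nitrogen on an aromatic ring. For the measured compounds named here, the one measured step that bears on this change is a 4.5-fold higher number from compound 1 to compound 3 (0.65 log units; beyond the scatter), a comparable substitution on the same nitrogen of the same core. Compound 2 carries a related group on a different core, so its value only shows that such a group need not raise the number. A modest rise is therefore expected, a 2.5-fold higher number from compound 1 to compound 4 (0.40 log units; beyond the scatter), and compound 4 is estimated at 50 mg/kg, in the range 20 mg/kg to 120 mg/kg.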

Compound 4, dose for half-maximal effect: 62 mg/kg
Estimate against measurement, compound 4: 1.2-fold (0.09 log units) below; the range from low to high includes it.
By their numbers in this assay, from the lowest: compounds 2 and 1 (each within the scatter of the next); then compounds 4 and 3 (each within the scatter of the next).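

In this assay, ((piperidin-1-yl)methyl)carbonyl on the nitrogen on the aromatic ring gives a 3.1-fold higher number from compound 1 to compound 4 (0.49 log units; beyond the scatter) and so moves the number the same way as the diethylamino counterpart in compound 3. Piperidin-1-yl in place of diethylamino gives a 1.5-fold lower number from compound 3 to compound 4 (0.16 log units; within the scatter) and so leaves the two amines indistinguishable on this read-out. No measured evidence accounts for the rise on substitution at this nitrogen. On these data alone, whether morpholin-4-yl in place of piperidin-1-yl, or a longer chain carrying the amine, would give a number like that of compound 1 remains open.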